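The compounds below may be only part of what the source reports. "The series", "measured", "known", "first", "only" and "open" are said of these compounds alone.

The measured compounds in a functional assay on HL-60 cells (Homo sapiens) for cytotoxicity, read by MTT assay, with a stated time of 48 h; on this read-out lower numbers stand for stronger inhibition and higher numbers for weaker inhibition:
Compound 1 `Fc1ccc2nc(-c3ccccc3)nc(Nc3ccccc3)c2c1` gives > 50000 nM, which is a limit of the assay and not a number.
Compound 2 `Fc1cccc(-c2nc(Nc3ccccc3Cl)c3cc(F)ccc3n2)c1` gives > 50000 nM, likewise a limit.
Compound 3 `Nc1ccc(Nc2nc(-c3cccc(F)c3)nc3ccc(F)cc23)cc1` gives > 50000 nM, again a limit.

Compound 2 therefore stands only at a limit in this assay, and all three values shown sit at that same limit (the limit of > 50000 nM in this assay, at which 3 of the 3 values shown sit). Compound 4 `Cc1cccc(Nc2nc(-c3cccc(F)c3)nc3ccc(F)cc23)c1` differs from compound 2 by 3-methylphenyl in place of 2-chlorophenyl on a nitrogen on an aromatic ring. The only measured step that touches this position, a step that the two limits leave unreadable from compound 2 to compound 3, cannot be read in size or direction, so nothing shown points either way. Compound 4 is therefore expected to remain at the limit as well, with a number no higher from compound 2 to compound 4 (the limit leaves the size open) expected to show no readable change. The estimate for compound 4 is 50000 nM, between 20000 nM and 100000 nM.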

Compound 4, half-maximal inhibitory concentration: > 50000 nM
Compound 4: a limit, no number; the forecaster's own chance of this, stated with the estimate: 85%; the middle value sits exactly at the limit.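

For the compounds shown here, compound 4, like compound 2 and compound 3, gives only a limit, so no step among them can be read in size or direction. The compounds shown leave open whether any group on this nitrogen would give a measurable value in this assay.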